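The source may report more compounds than this note shows. Statements on the series, on what has been measured and on what is new or still open speak of the compounds shown alone.

Compound 1, `COc1ccc2nc(NC(=O)CNC(=O)c3nn(-c4ccccc4)c(=O)c4ccccc34)sc2c1`, gives 210 nM in an assay on L cells for inhibition of Protein-serine O-palmitoleoyltransferase porcupine (Mus musculus), read by reporter gene assay, with a stated time of 24 h; a higher number here means that more compound is needed for the effect, a lower number that less compound is needed.
Compound 2, `O=C(CNC(=O)c1nn(-c2ccccc2)c(=O)c2ccccc12)Nc1nccs1`, reaches only a limit of the assay in this assay, > 25000 nM.

Compound 2 thus stands at the weak end of the two measured values, and its value is a limit rather than a number (the limit of > 25000 nM in this assay, at which 1 of the 2 values shown sits). Compound 3, `O=C(CNC(=O)c1nn(-c2ccccc2)c(=O)c2ccccc12)Nc1nc2ccc(F)cc2s1`, differs from compound 2 by 6-fluoro-1,3-benzothiazol-2-yl in place of 1,3-thiazol-2-yl on an amide-type nitrogen. Within the data shown here, the one measured step bears on this directly: an at least 110-fold higher number from compound 1 to compound 2 (2.07 log units; beyond the scatter), a large loss when the fused benzothiazole was cut back to the bare thiazole. Compound 3 restores the benzothiazole, carrying a fluorine where compound 1 carries a methoxy group; how that exchange acts is not shown by any measured pair. The expected step is therefore a large gain, an at least 62-fold lower number from compound 2 to compound 3 (1.79 log units; beyond the scatter), back toward the region of compound 1, whose value is 210 nM. Compound 3 is accordingly estimated at 400 nM in this assay, within a range from 100 nM to 3000 nM.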

Compound 3, half-maximal effective concentration: 470 nM
Compound 3: the middle estimate sits 1.2-fold (0.07 log units) below what was measured, and the stated range covers the measured number.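

With 6-fluoro-1,3-benzothiazol-2-yl in place of 1,3-thiazol-2-yl on the amide-type nitrogen, this assay shows an at least 53-fold lower number from compound 2 to compound 3 (1.72 log units; beyond the scatter), so the large loss seen earlier is recovered by a group that lacks the methoxy of compound 1. Among these compounds, the exchange of methoxy for fluoro on the aromatic carbon, which no earlier pair covered, gives a 2.2-fold higher number from compound 1 to compound 3 (0.35 log units; beyond the scatter), a modest step, so the methoxy group is not needed to stay near the value of compound 1. The large step from compound 2 has only a lower bound, since compound 2 gives a limit of the assay and not a number: the limit of > 25000 nM in this assay, at which 1 of the 3 values shown sits.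

The compounds shown leave open how the plain 1,3-benzothiazol-2-yl, or an amine in place of the fluoro, would read. Going by these compounds, how this assay would respond to a longer chain in place of the one carrying the two amide groups also remains open.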